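Adding one methyl to a weak short-chain compound

A few compounds are considered here, and "the series" means these few. Any claim that something is new, unique, unknown or untested is made for them only; others in the source may bear on it.

In a functional assay on Jurkat cells (Homo sapiens) for cytotoxicity (a lower number here means a stronger inhibitor, a higher number a weaker inhibitor), compound 1 `CCCC/C=C/C1=C(CO)[C@H](O)[C@H]2O[C@H]2C1=O` gives 15000 nM. Compound 2 `C/C=C/C1=C(CO)[C@H](O)[C@H]2O[C@H]2C1=O` gives > 80000 nM, which is a limit of the assay and not a number. Compound 2 therefore has no exact position on the scale, and only its limit is known.

Compound 3 `C/C=C(\C)C1=C(CO)[C@H](O)[C@H]2O[C@H]2C1=O` carries 1-methylprop-1-en-1-yl in place of prop-1-en-1-yl on a double-bonded ring carbon. For the measured compounds named here, the only measured guide is an at least 5.3-fold higher number from compound 1 to compound 2 (0.72 log units; beyond the scatter), which is beyond the scatter and comes from hydrogen in place of propyl on a saturated chain carbon bound to a double-bonded chain carbon. The new methyl is a smaller addition than that propyl, and it sits elsewhere, so only a slight gain is expected. The expected step is an at least 1.3-fold lower number from compound 2 to compound 3 (0.12 log units; that floor lies within the scatter), towards a lower number in this assay. For compound 3 the estimated value is 60000 nM, with an expected range from 20000 nM to 120000 nM.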

Compound 3, half-maximal inhibitory concentration: > 80000 nM
Compound 3 was reported as a limit (the forecaster's own chance of this, stated with the estimate: 55%); middle value at least 1.3-fold (0.12 log units) from the limit.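

Compound 2 and compound 3 are both reported only as a limit and not as a number, so no step can be read between them: the limit of > 80000 nM in this assay, at which 2 of the 3 values shown sit.

Going by these compounds, whether 1-methylprop-1-en-1-yl in place of prop-1-en-1-yl changes cytotoxicity at all remains open.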